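The source may hold more compounds than are shown below. What is called first, only, known or untested is meant among the compounds shown, and "the series" means these compounds.

Measured compounds:
- Compound 1, `COc1ccc(C2CC(c3ccc(OC)c(OC)c3)=NN2C(=O)CO[N+](=O)[O-])c(OC)c1`: in a functional assay on the whole organism (strain albino) for inhibition, with Rattus norvegicus as the target, read by paw edema, with stated times of 30 min and 3 h, at a dose of 100 mg/kg by the oral route (on this read-out higher numbers stand for more inhibition at the one dose given (going by the name of the read-out) and lower numbers for less inhibition), compound 1 gives 58%.
- Compound 2, `COc1ccc(C2=NN(C(=O)CNc3ccc(/C(C)=N/O)cc3)C(c3ccco3)C2)cc1OC`: in this assay compound 2 gives 46%.

Compound 2 stands at the lower of the two numbers seen so far; compound 1 sits above it by a gap that is beyond the usual scatter. For the measured compounds named here, no single-point step between these two measured compounds is available, since they differ in more than one place, so the pair shows only that compound 1 is the higher of the two.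

The next compound is compound 3, `COc1ccc(C2CC(c3ccc(OC)c(OC)c3)=NN2C(=O)CNc2ccc(/C(C)=N/O)cc2)c(OC)c1`. It is reached from compound 2 by one change: 2,4-dimethoxyphenyl in place of furan-2-yl on a saturated ring carbon. Compound 3 thus carries the same pair of methoxyphenyl groups on its core as compound 1, while keeping the side chain of compound 2.

Going by the values given here, no measured step shows the effect of this change alone. A modest upward step is expected for compound 3 because compound 1 gives 58% with the same group on its core, but that comparison is confounded by the different side chain, so the expectation is kept small. The expected step of a number 6 percentage points higher from compound 2 to compound 3 (within the scatter) lies within the scatter rather than clearly beyond it. Compound 3 is estimated to give 52%, in a range from 38% to 66%.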

Compound 3, a percentage reported as inhibition, in the whole organism at one dose (the size of the read-out at that dose, not a potency): 46%
Beside the measured number, compound 3's estimate is 6 percentage points above it, and the stated range covers the measured number.
By their numbers in this assay, from the lowest: compounds 2 and 3 (each within the scatter of the next); then compound 1.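

In this assay, 2,4-dimethoxyphenyl in place of furan-2-yl on the saturated ring carbon gives no change at the digits printed from compound 2 to compound 3 (within the scatter) and so the read-out does not tell these two groups apart at this position, even though the entering group has 10 heavy atoms against 5 and a six-membered aromatic ring of carbon only in place of a five-membered one with a hetero atom. For the compounds shown here, with 2,4-dimethoxyphenyl held on the shared core, the side chain can now be read alone: the group of 11 heavy atoms in place of the group of 4 heavy atoms on the saturated chain carbon bound to the carbonyl carbon gives a number 12 percentage points lower from compound 1 to compound 3 (beyond the scatter) and this one-place step shows a difference that the first pair of compounds could not place. Nothing given here accounts for either step.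

Going by these compounds, whether the flat result at the saturated ring carbon would hold for a small alkyl group such as methyl, or for a carboxylic acid, remains open. On these data alone, it is also open which part of the group of 11 heavy atoms goes with the step, and whether a shorter chain ending in an amine would read differently at this single dose.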